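Removing a Methoxy Group From a Bis-indolyl Quinone Core

The source may report more compounds than this note shows. Statements on the series, on what has been measured and on what is new or still open speak of the compounds shown alone.

Of the compounds shown here, three have been measured in a functional assay on MDA-MB-231 cells (Homo sapiens) for antiproliferative activity, read by CCK-8 assay, with a stated time of 48 h; on this read-out higher numbers stand for weaker inhibition and lower numbers for stronger inhibition. Compound 1 `COc1ccc2[nH]c(C)c(C3=C(Cl)C(=O)C(c4c(-c5ccc(C)cc5)[nH]c5ccccc45)=C(Cl)C3=O)c2c1` gives 4.15 ug/mL, and compound 2 `Cc1ccc(-c2[nH]c3ccccc3c2C2=C(Cl)C(=O)C(c3c(C)[nH]c4ccccc34)=C(Cl)C2=O)cc1` gives 4.21 ug/mL. The two differ in one place only, (hydrogen in place of methoxy on an aromatic carbon), and that change gave a 1.0-fold higher number from compound 1 to compound 2 (0.01 log units; within the scatter). Compound 3 `COc1ccc2[nH]c(C)c(C3=C(Br)C(=O)C(Br)=C(c4c(-c5ccccc5)[nH]c5ccccc45)C3=O)c2c1` gives 7.67 ug/mL in this assay; its core differs from the core of compound 1 in more than one place, and that difference is not broken down here. The values of compound 3 and compound 1 lie within the scatter of each other, as do those of compound 3 and compound 2.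

Compound 4 `Cc1[nH]c2ccccc2c1C1=C(Br)C(=O)C(Br)=C(c2c(-c3ccccc3)[nH]c3ccccc23)C1=O` has not yet been measured. It stands to compound 3 as compound 2 stands to compound 1: the difference is hydrogen in place of methoxy on an aromatic carbon, and the place of the change is described in the same words for both pairs, so it counts as the same change. Because the same change from compound 1 to compound 2 gave a 1.0-fold higher number from compound 1 to compound 2 (0.01 log units; within the scatter), the expected step from compound 3 to compound 4 is a 1.0-fold higher number from compound 3 to compound 4 (0.00 log units; within the scatter). The estimate for compound 4 in this assay is 7.7 ug/mL, with a likely range from 3.8 ug/mL to 15.5 ug/mL.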

Compound 4, half-maximal inhibitory concentration: 4.33 ug/mL
For compound 4 the middle estimate is 1.8-fold (0.25 log units) above the measured one; low and high end bracket the measured number.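

Replacing methoxy with hydrogen on the second core gave a 1.8-fold lower number from compound 3 to compound 4 (0.25 log units; within the scatter) in this assay, so this step, like the earlier one on the first core, is no larger than the usual spread between repeated measurements. Set side by side, the two steps cannot be told apart, which means that on these two cores the change carries over as far as this read-out can show: the same change on two cores in this assay, a 1.0-fold higher number (0.01 log units; within the scatter) from compound 1 to compound 2 and a 1.8-fold lower number (0.25 log units; within the scatter) from compound 3 to compound 4, 1.8-fold (0.25 log units) apart, within the scatter of two such steps This does not prove that the methoxy group makes no difference across the series, or that the two steps are truly equal, as only two pairs are compared and a small real difference could be hidden in the scatter.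

Going by these compounds, whether a different group at the same place, such as an amine, a carboxylic acid or a longer alkoxy chain, would shift the number beyond the scatter remains open. Also open, on these data alone, is whether the same change would behave alike on other cores.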